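The source may hold more compounds than are shown below. What is called first, only, known or untested is meant among the compounds shown, and "the series" means these compounds.

Compound 2 `CCN(CC)S(=O)(=O)c1ccc(S(=O)(=O)N2CCC[C@@H](C(=O)NC)C2)cc1` is one of two compounds with a result in a functional assay on MIA PaCa-2 cells (Homo sapiens) for inhibition, read by MTT assay, with a stated time of 3 days; a higher number here means a weaker inhibitor, a lower number a stronger inhibitor. In this assay compound 2 gives only a limit, > 10000 nM, and not a number. Compound 1 `CCN(CC)S(=O)(=O)c1ccc(S(=O)(=O)N2CCC[C@@H](C(=O)N(C)C(C)C)C2)cc1` likewise gives only a limit in this assay, > 10000 nM. Going by the values given here, the one measured step, a step that the two limits leave unreadable from compound 1 to compound 2, therefore cannot be read in size or direction. Both results sit at the limit of > 10000 nM in this assay, at which 2 of the 2 values shown sit.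

Compound 3 `CCN(CC)S(=O)(=O)c1ccc(S(=O)(=O)N2CCC[C@@H](C(=O)NC3CN(C(=O)OC(C)(C)C)C3)C2)cc1` differs from compound 2 in one place: 1-(tert-butoxycarbonyl)azetidin-3-yl in place of methyl on an amide-type nitrogen. Among the compounds with values here, no measured step covers a change of this kind, and the only measured step that touches the same amide-type nitrogen is unreadable, so nothing known here sets a size or a direction for the change from compound 2 to compound 3 in this assay. Compound 2 stands at the limit, and a change of unknown effect starting from there most plausibly leaves compound 3 at or around the same limit, though a shift in either direction cannot be ruled out. Compound 3 is therefore estimated at 15000 nM, within 3000 nM to 60000 nM. This corresponds to an expected step that the limit leaves unreadable from compound 2 to compound 3.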

Compound 3, half-maximal inhibitory concentration: > 10000 nM
Compound 3: no number, only a limit; the forecaster's own chance of this, stated with the estimate: 70%; the middle value is on the limit's open side.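

Compound 3 also gives only a limit in this assay, > 10000 nM, and not a number. Its steps from compound 1 and compound 2 therefore cannot be read in size or direction, and all three results coincide: the limit of > 10000 nM in this assay, at which 3 of the 3 values shown sit.

The compounds shown leave open what number any of them would give in this assay, and whether any group on this amide-type nitrogen yields a measurable value.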